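A heteroaryl swap on a shared core

The source may hold more compounds than are shown below. What is called first, only, known or untested is meant among the compounds shown, and "the series" means these compounds.

Of the compounds shown here, three have been measured in a functional assay on CHO-K1 cells for antagonist activity at adenosine receptor A1 (Homo sapiens), read by a beta-galactosidase reporter and cAMP accumulation, with stated times of 15 min and 6 h (a higher number here means a weaker inhibitor, a lower number a stronger inhibitor), so far. Compound 1 `Cc1ccc(-c2nc(N)c3cc(C(C)c4ccccc4)sc3n2)o1` gives 439 nM, compound 2 `Nc1nc(-c2cnco2)nc2sc(Cc3ccccc3)cc12` gives 106 nM, and compound 3 `N#Cc1cccc(-c2nc(N)c3cc(Cc4ccccc4Cl)sc3n2)c1` gives 24.8 nM. Compound 2 thus stands second highest of the three numbers: its nearest neighbour is compound 1, whose number is higher by more than the usual scatter, and the furthest is compound 3, whose number is lower by a similar margin in the other direction. Going by the values given here, none of these three pairs differs in only one place, so no single-point step is available to lean on.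

Compound 4 `Nc1nc(-c2ncccn2)nc2sc(Cc3ccccc3)cc12` is the next compound to be measured. It differs from compound 2 in one place: pyrimidin-2-yl in place of 1,3-oxazol-5-yl on an aromatic carbon. The new group sits on the same aromatic carbon, between two ring nitrogen atoms of the shared core. Among the compounds with values here, with no step to guide the expectation, a change in this assay of modest size in either direction, or none beyond the scatter, seems equally plausible. The expected step is a 1.4-fold higher number from compound 2 to compound 4 (0.15 log units; within the scatter). Compound 4 is therefore estimated at 150 nM, within a range from 40 nM to 550 nM.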

Compound 4, inhibition constant: 618 nM
Beside the measured number, compound 4's estimate is 4.1-fold (0.61 log units) below it; the whole stated range lies below it.
By their numbers in this assay, from the lowest: compound 3; then compound 2; then compounds 1 and 4 (each within the scatter of the next).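

Going by these compounds alone, this is the first step here that changes one place only, and it shows that the group on the aromatic carbon between two ring nitrogen atoms of the shared core matters in this assay: pyrimidin-2-yl in place of 1,3-oxazol-5-yl gives a 5.8-fold higher number from compound 2 to compound 4 (0.77 log units; beyond the scatter) and so moves the number beyond the usual scatter. The two groups have the same counts of hydrogen-bond donors and acceptors and neither carries a net charge, so those counts do not separate them, while ring size and the hetero atoms do differ. Nothing measured here accounts for the weaker inhibition.

Still open, as far as these compounds go, is whether ring size or the placing of the ring nitrogen atoms sets this difference, which a pyridin-2-yl or 1,3-thiazol-5-yl group at the same carbon could help to separate. Also open, from the compounds shown here alone, is whether the same swap gives a similar step on a core that also carries a methoxy group.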